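From Ethoxycarbonyl to Carboxy: Compound 3 and Compound 4

The source may hold more compounds than are shown below. What is called first, only, known or untested is meant among the compounds shown, and "the series" means these compounds.

Measured in a functional assay on U-87MG ATCC cells for cytotoxicity against U-87 MG (Homo sapiens), read by colorimetric assay and MTT assay; a higher number here means a weaker inhibitor, a lower number a stronger inhibitor:
Compound 1 `COc1cccc2cc(-c3ccccc3)c(O)nc12`: 10000 nM
Compound 2 `COc1cc(OC)c2cc(-c3ccc(OCc4ccccc4)cc3)c(O)nc2c1`: 10000 nM
Compound 3 `CCOC(=O)Cn1c(=O)c(-c2ccc(OC)cc2)cc2c(OC)cc(OC)cc21`: 10000 nM

Compound 3 stands level with compound 1 and compound 2, and the three readings lie within the scatter of one another. Compound 4 `COc1ccc(-c2cc3c(OC)cc(OC)cc3n(CC(=O)O)c2=O)cc1` has hydrogen in place of ethyl on an oxygen next to a carbonyl group, which turns ethoxycarbonyl into carboxy. Among the measured compounds shown here, no measured pair differs in one place, so the data offer no direct precedent for this change. With compound 3 at 10000 nM as the starting point, no step beyond the scatter is expected in this assay, in either direction. The expected change is no change at the digits printed from compound 3 to compound 4 (within the scatter). Compound 4 is estimated at 10000 nM, with an expected range from 5000 nM to 20000 nM.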

Compound 4, half-maximal inhibitory concentration: 10000 nM
Compound 4: middle estimate and measured number agree at the digits printed; measured number inside the range.
By their numbers in this assay, from the lowest: compounds 1, 2, 3 and 4 (each within the scatter of the next).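

In this assay, hydrogen in place of ethyl on an oxygen next to a carbonyl group, which turns ethoxycarbonyl into carboxy, gives no change at the digits printed from compound 3 to compound 4 (within the scatter). Among the compounds shown here, this is the first pair here that differs in one place, and it shows that this exchange at the end of the (ethoxycarbonyl)methyl group leaves the reading unmoved. Nothing available explains this result.

The compounds shown leave open whether a primary amide or an amine at this place, or a longer chain carrying the carboxy group, would shift the reading.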